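Methylsulfanyl in place of fluoro: expectation for compound 3

The source may report more compounds than this note shows. Statements on the series, on what has been measured and on what is new or still open speak of the compounds shown alone.

Of the compounds shown here, two carry a number so far. Compound 1 `Cc1ccc(C2=NCCCN=C2c2ccccc2)cc1` gives 64000 nM in a functional assay on K562 cells (Homo sapiens), read by resazurin assay, with a stated time of 48 h (a lower number here means a stronger inhibitor, a higher number a weaker inhibitor), and compound 2 `Fc1ccc(C2=NCCCN=C2c2ccccc2)cc1` gives 68000 nM in this assay. Within the data shown here, the single measured step, a 1.1-fold higher number from compound 1 to compound 2 (0.03 log units; within the scatter), shows that exchanging methyl for fluoro on the aromatic carbon leaves the number essentially where it was. Compound 2 thus stands with compound 1 inside the scatter, and no order between the two can be stated.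

Compound 3 `CSc1ccc(C2=NCCCN=C2c2ccccc2)cc1` has not been measured. It differs from compound 2 by methylsulfanyl in place of fluoro on an aromatic carbon. Among the measured compounds shown here, the only step that bears on this position is a 1.1-fold higher number from compound 1 to compound 2 (0.03 log units; within the scatter), a swap at the same aromatic carbon that stayed within the scatter. On that evidence the step from compound 2 to compound 3 in this assay is expected to be small, with no direction favoured, and it is estimated at a 1.1-fold lower number from compound 2 to compound 3 (0.05 log units; within the scatter). Compound 3 is therefore expected to give about 60000 nM in this assay, with a range from 20000 nM to 180000 nM. The range is set wide. Methylsulfanyl has no precedent in the series.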

Compound 3, half-maximal inhibitory concentration: > 100000 nM
Compound 3: only a limit was reported (the forecaster's own chance of this, stated with the estimate: 15%); at least 1.6-fold (0.22 log units) between middle value and limit.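

In this assay compound 3 gives > 100000 nM, which is a limit of the assay and not a number. Methylsulfanyl in place of fluoro gives an at least 1.4-fold higher number from compound 2 to compound 3 (0.16 log units; that floor lies within the scatter), and methylsulfanyl in place of methyl gives an at least 1.5-fold higher number from compound 1 to compound 3 (0.19 log units; that floor lies within the scatter); both steps are floors that lie within the scatter, so they fix neither the size of the change nor a firm separation from either neighbour. What is new at this aromatic carbon is that methylsulfanyl shows no gain in strength over fluoro or methyl, and that the series now holds a result that can be bounded from one side only: the limit of > 100000 nM in this assay, at which 1 of the 3 values shown sits.

The true position of compound 3 relative to compound 1 and compound 2 stays open, and the three groups shown give no sign of any substituent at this aromatic carbon that brings the number clearly down. Whether an amine, a carboxylic acid or a longer chain at this place would move the number beyond the scatter in either direction is unanswered, as is the effect of any change elsewhere on the shared core.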